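The source may report more compounds than this note shows. Statements on the series, on what has been measured and on what is new or still open speak of the compounds shown alone.

Measured in a functional assay on COLO 205 cells (Homo sapiens) for inhibition, read by sulforhodamine B assay, with a stated time of 48 h, tested at 50 uM; on this read-out lower numbers stand for less inhibition of growth and higher numbers for more inhibition of growth at the one concentration tested:
compound 1 `COc1cc(/C=C/C(=O)/C=C/c2cccs2)ccc1OCc1cn(CCOc2cc(=O)oc3ccccc23)nn1`: 66%
compound 2 `COc1cccc(/C=C/C(=O)/C=C/c2ccc(OCc3cn(CCCCCOc4cc(=O)oc5ccccc45)nn3)c(OC)c2)c1`: 34%
compound 3 `COc1cccc(/C=C/C(=O)/C=C/c2ccc(OCc3cn(CCOc4cc(=O)oc5ccccc45)nn3)c(OC)c2)c1`: 69%

Compound 2, at 34%, has the lowest of these three numbers, and both of the others lie clearly above it. Compound 4 `COc1cc(/C=C/C(=O)/C=C/c2cc(OC)c(OC)c(OC)c2)ccc1OCc1cn(CCCCCOc2cc(=O)oc3ccccc23)nn1`, not yet measured, differs from compound 2 in one place: 3,4,5-trimethoxyphenyl in place of 3-methoxyphenyl on a double-bonded chain carbon bound to a double-bonded chain carbon. Among the compounds with values here, only one measured step swaps a group at this same place: a number 3 percentage points higher from compound 1 to compound 3 (within the scatter). Within the data shown here, that step was seen on a different chain from the one in compound 2, so it is only a loose guide. Going by it, no change beyond the scatter is expected in this assay. The expected result is a number 4 percentage points higher from compound 2 to compound 4 (within the scatter). For compound 4 the estimate is 38%, with an expected range of 22% to 55%.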

Compound 4, percent growth inhibition at one concentration: 51%
The estimate for compound 4 lay 13 percentage points below the measured number; measured number inside the range.
By their numbers in this assay, from the lowest: compound 2; then compound 4; then compounds 1 and 3 (each within the scatter of the next).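

In this assay, the group at this place, on a double-bonded chain carbon bound to a double-bonded chain carbon, can clearly change the result: 3,4,5-trimethoxyphenyl in place of 3-methoxyphenyl gives a number 17 percentage points higher from compound 2 to compound 4 (beyond the scatter). Within the data shown here, the only earlier swap here, a number 3 percentage points higher from compound 1 to compound 3 (within the scatter), showed no such shift. Still open, from the compounds shown here alone, is whether 3,4,5-trimethoxyphenyl gives a similar rise on the chain of compound 3, and what a phenyl ring carrying an amine or a carboxylic acid would do here. The data shown give no reason for this rise.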